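A few compounds are considered here, and "the series" means these few. Any claim that something is new, unique, unknown or untested is made for them only; others in the source may bear on it.

Four compounds sharing one core are considered here: compound 1 `O=c1ccc2cc(OCc3cc(-c4ccc(Cl)cc4)no3)ccc2o1`, compound 2 `O=c1ccc2cc(OCc3cn(-c4cccc(CO)c4)nn3)ccc2o1`, compound 3 `O=c1ccc2cc(OCc3cn(-c4ccccc4Cl)nn3)ccc2o1` and the unmeasured compound 4 `O=c1ccc2cc(OCc3cn(-c4ccc([N+](=O)[O-])cc4)nn3)ccc2o1`. In a functional assay on A549 cells (Homo sapiens) for cytotoxicity, read by MTT assay, with a stated time of 48 h (a higher number here means a weaker inhibitor, a lower number a stronger inhibitor), compound 1 gives "not determined" (no result reported), compound 2 gives 35100 nM and compound 3 gives 17100 nM, the lowest of the two numbers, separated from compound 2 by the step of a 2.1-fold lower number from compound 2 to compound 3 (0.31 log units; beyond the scatter). Compound 4 differs from compound 3 by 4-nitrophenyl in place of 2-chlorophenyl on an aromatic nitrogen. Among the measured compounds shown here, only that one step, a change of the aryl group on the same aromatic nitrogen, bears on this move, and it was modest; no step involving a nitrophenyl exists. Compound 4 is therefore expected to show a step of a 1.2-fold higher number from compound 3 to compound 4 (0.07 log units; within the scatter), within the scatter, with an estimated value of 20000 nM and a range from 8000 nM to 50000 nM.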

Compound 4, half-maximal inhibitory concentration: 33600 nM
Compound 4: middle estimate off by 1.7-fold (0.23 log units), on the low side, and the stated range covers the measured number.
By their numbers in this assay, from the lowest: compounds 3, 4 and 2 (each within the scatter of the next, the first and the last beyond it).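

In this assay the 4-nitrophenyl group on this aromatic nitrogen stands apart from neither earlier aryl group, with a 2.0-fold higher number from compound 3 to compound 4 (0.29 log units; within the scatter) and a 1.0-fold lower number from compound 2 to compound 4 (0.02 log units; within the scatter) both within the scatter. Only compound 2 and compound 3 lie beyond the scatter of each other, so the numbers for these three aryl groups stay close together. No available evidence bears on this result.

Still open, on these data alone, is whether an amine or a carboxylic acid on the phenyl ring, or a longer chain in place of the phenyl ring, would shift the number further.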